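Oxolane attachment point in the sulfonamide series

A few compounds are considered here, and "the series" means these few. Any claim that something is new, unique, unknown or untested is made for them only; others in the source may bear on it.

In an ADME assay on MDCKII-LE cells (Canis lupus familiaris) for permeability, read by transwell migration, in the apical to basolateral direction (on this read-out lower numbers stand for lower permeability and higher numbers for higher permeability), compound 1 (`CC1(C)CO[C@@H]1CN([C@H](CCC(F)(F)F)C(N)=O)S(=O)(=O)c1ccc(Cl)cc1`) gives 22.3 10^-6 cm/s while compound 2 (`NC(=O)[C@@H](CCC(F)(F)F)N(C[C@H]1COCCO1)S(=O)(=O)c1ccc(Cl)cc1`) gives 20.6 10^-6 cm/s and compound 3 (`NC(=O)[C@@H](CCC(F)(F)F)N(C[C@H]1CCOC1)S(=O)(=O)c1ccc(Cl)cc1`) gives 21.7 10^-6 cm/s on the same read-out. Compound 3 stands within the scatter of both others. Compound 4 (`NC(=O)[C@@H](CCC(F)(F)F)N(C[C@@H]1CCCO1)S(=O)(=O)c1ccc(Cl)cc1`) differs from compound 3 by one change (oxolan-2-yl in place of oxolan-3-yl on a saturated chain carbon bound to a sulfonamide nitrogen) with oxolan-2-yl in place of oxolan-3-yl on a saturated chain carbon bound to a sulfonamide nitrogen. Three measured ring swaps at that place bear on it: a 1.1-fold lower number from compound 1 to compound 2 (0.03 log units; within the scatter) and a 1.0-fold lower number from compound 1 to compound 3 (0.01 log units; within the scatter) and a 1.1-fold higher number from compound 2 to compound 3 (0.02 log units; within the scatter) all stay within the scatter. None of them is this exact swap, so the support is indirect. In this assay no step beyond the scatter is therefore expected, and the estimated step is a 1.0-fold lower number from compound 3 to compound 4 (0.01 log units; within the scatter) with no direction favoured. Compound 4 is estimated at 21 10^-6 cm/s (expected range 13 10^-6 cm/s to 34 10^-6 cm/s).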

Compound 4, apparent permeability: 22.4 10^-6 cm/s
For compound 4 the middle estimate is 1.1-fold (0.03 log units) below the measured one; measured number inside the range.
By their numbers in this assay, from the lowest: compounds 2, 3, 1 and 4 (each within the scatter of the next).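

Unlike the earlier ring swaps, this change keeps the same atoms and alters only the oxolane attachment point, and it produces no step beyond the scatter in this assay (a 1.0-fold higher number from compound 3 to compound 4 (0.01 log units; within the scatter)). The oxolan-2-yl group also stays within the scatter of the other two rings (a 1.1-fold higher number from compound 2 to compound 4 (0.04 log units; within the scatter); a 1.0-fold higher number from compound 1 to compound 4 (0.00 log units; within the scatter)), so all four compounds read alike at this place. No supporting data bear on why the read-out stays level.

Open, from the compounds shown here alone, is whether an amine or a carboxylic acid at this place would give the same read-out. Going by these compounds, the opposite configuration at the oxolan-2-yl stereocentre is also open.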